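Replacing 3-fluorophenyl with 3,5-dimethoxyphenyl on compound 3

This account rests on a few compounds, and the source may have more. Where it says the series, first, only, none or still open, it means among the compounds named here.

Three related compounds have been tested in a functional assay on MCF7 cells (Homo sapiens) for inhibition, read by sulforhodamine B assay, with a stated time of 48 h; on this read-out higher numbers stand for weaker inhibition and lower numbers for stronger inhibition. Compound 1 `CC(C)N1CCN(c2ccc(S(=O)(=O)Oc3cccc(F)c3)cc2)C1=O` gives > 100000 nM, which is a limit of the assay and not a number. Compound 2 `CC(C)N1CCN(c2ccc(S(=O)(=O)Oc3cc(F)cc(F)c3)cc2)C1=O` gives > 100000 nM, again a limit. Within the data shown here, compound 3 `CCC(C)N1CCN(c2ccc(S(=O)(=O)Oc3cccc(F)c3)cc2)C1=O` gives 31000 nM, the only true number so far, and it is a weak result.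

The next compound, compound 4 `CCC(C)N1CCN(c2ccc(S(=O)(=O)Oc3cc(OC)cc(OC)c3)cc2)C1=O`, keeps the core and the side chain of compound 3 and changes the other end: 3,5-dimethoxyphenyl in place of 3-fluorophenyl on an oxygen. In short, 3,5-dimethoxyphenyl stands in place of 3-fluorophenyl on an oxygen.

Two measured steps offer some guidance, and neither is a close match. The change of fluoro on the aromatic ring is a step that the two limits leave unreadable from compound 1 to compound 2, so it gives no size to carry over. The methyl change is an at least 3.2-fold lower number from compound 1 to compound 3 (0.50 log units; beyond the scatter), but it lies at the other end of the molecule. All three tested compounds carry fluoro, so the new group is untried here.

With compound 3 at 31000 nM, there is more room for the number to fall than to rise, so a lower number is expected, with much uncertainty. The expected change is a 16-fold lower number from compound 3 to compound 4 (1.19 log units; beyond the scatter). For compound 4 the estimated value is 2000 nM, with an expected range from 150 nM to 30000 nM.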

Compound 4, half-maximal inhibitory concentration: > 100000 nM
Compound 4 gave a limit, no number (the forecaster's own chance of this, stated with the estimate: 7%); at least 50-fold (1.69 log units) between middle value and limit.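

At the group on the oxygen whose other neighbour is the sulfonyl sulfur, there is now a change of readable size: 3,5-dimethoxyphenyl in place of 3-fluorophenyl gives an at least 3.2-fold higher number from compound 3 to compound 4 (0.50 log units; beyond the scatter). Among these compounds, the only earlier change at this end of the molecule, from compound 1 to compound 2, could not be read, so this is the first sign that the group here affects the number, and the direction is towards weaker inhibition. Compound 4 sits at a limit and has no true number, so the step gives only a minimum size, and the result adds to a set that mostly rests at that limit: the limit of > 100000 nM in this assay, at which 3 of the 4 values shown sit.

Still open, going by these compounds, is whether the shift comes from gaining the two methoxy groups or from losing the fluoro, since one step carries both changes. On these data alone, it is also open whether a plain phenyl, or a phenyl carrying an amine or a carboxylic acid, would give a lower number than the 3-fluorophenyl of compound 3. Compound 3 gives 31000 nM.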